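This account rests on a few compounds, and the source may have more. Where it says the series, first, only, none or still open, it means among the compounds named here.

Among the measured compounds shown here, compound 2 `O=C(/C=C/c1ccc(Cl)cc1)c1ccccc1O` is one of only two measured compounds here. In an assay on isolated protein for inhibition of Amine oxidase [flavin-containing] B (Homo sapiens) (a lower number here means a stronger inhibitor, a higher number a weaker inhibitor), compound 2 gives 158000 nM, the top of the two numbers shown, yet this sits within the scatter of compound 1 `O=C1/C(=C/c2ccc(Cl)cc2)COc2ccccc21`, which in this assay gives 155000 nM. Compound 3 `O=C(/C=C/c1ccc(Cl)cc1)c1ccc(F)cc1O` differs from compound 2 by fluoro in place of hydrogen on an aromatic carbon. For the measured compounds named here, no measured pair shows a step of this kind, so its size is unknown; the expected step is a 1.3-fold lower number from compound 2 to compound 3 (0.12 log units; within the scatter), nothing beyond the scatter. Compound 3 is estimated at 120000 nM, between 40000 nM and 400000 nM.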

Compound 3, half-maximal inhibitory concentration: 70800 nM
The estimate for compound 3 lay 1.7-fold (0.23 log units) above the measured number; low and high end bracket the measured number.
By their numbers in this assay, from the lowest: compound 3; then compounds 1 and 2 (each within the scatter of the next).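

In this assay, among the compounds shown here, fluoro in place of hydrogen gives a 2.2-fold lower number from compound 2 to compound 3 (0.35 log units; beyond the scatter), the first measured step at this aromatic carbon, meta to a hydroxy group and para to a large group. It shows that adding this one heavy atom here can move the number beyond the scatter, though only modestly. Nothing measured here bears on what lies behind this step. On these data alone, whether chloro, methoxy or an amine at this carbon would give a similar step stays open. So does whether the same fluoro change would carry over to the core of compound 1.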